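A few compounds are considered here, and "the series" means these few. Any claim that something is new, unique, unknown or untested is made for them only; others in the source may bear on it.

Of the compounds shown here, three built on one shared core have been measured so far. Compound 1 `Cc1cc(Oc2ccc(C(F)(F)F)cc2Cl)ccc1CC1SC(=O)NC1=O` gives 18 nM in a functional assay for agonist activity at Free fatty acid receptor 1 (Homo sapiens), read by FLIPR, in the presence of a further agent that is not named here; on this read-out lower numbers stand for an effect already at smaller amounts and higher numbers for an effect only at larger amounts of compound. Compound 2 `O=C1NC(=O)C(Cc2ccc(Oc3ccc(Cl)cc3Cl)cc2)S1` gives 101 nM in this assay, and compound 3 `O=C1NC(=O)C(Cc2ccc(Oc3ccccc3Cl)cc2)S1` gives 1190 nM in this assay. Compound 3 thus stands at the highest of the three numbers; its nearest neighbour is compound 2, and compound 1 lies furthest from it.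

Among the measured compounds shown here, the one measured step that alters the outer ring is a 12-fold higher number from compound 2 to compound 3 (1.07 log units; beyond the scatter), a large change for a single substituent.

Compound 4 `O=C1NC(=O)C(Cc2ccc(Oc3ccc(C(F)(F)F)cc3Cl)cc2)S1` differs from compound 3 in one place: trifluoromethyl in place of hydrogen on an aromatic carbon. This re-occupies the position that was emptied going from compound 2 to compound 3. Compound 1, which also carries a trifluoromethyl and a chloro group on its outer ring, gives 18 nM in this assay, which suggests that this pairing of groups is well tolerated.

Because a 12-fold higher number from compound 2 to compound 3 (1.07 log units; beyond the scatter) was large, compound 4 is expected to show a 24-fold lower number from compound 3 to compound 4 (1.38 log units; beyond the scatter) in this assay, a clear drop in the number. For compound 4 the estimate in this assay is 50 nM, expected to fall between 15 nM and 160 nM.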

Compound 4, half-maximal effective concentration: 78 nM
Beside the measured number, compound 4's estimate is 1.6-fold (0.19 log units) below it; measured number inside the range.
By their numbers in this assay, from the lowest: compound 1; then compounds 4 and 2 (each within the scatter of the next); then compound 3.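

In this assay the step of a 15-fold lower number from compound 3 to compound 4 (1.18 log units; beyond the scatter) shows that the position para to a large group and meta to a chloro group does not depend on the chloro group of compound 2 alone, since trifluoromethyl, with its 4 heavy atoms, also gives a far lower number than hydrogen there. The two groups cannot be told apart at this position: a 1.3-fold lower number from compound 2 to compound 4 (0.11 log units; within the scatter) and so neither can be ranked above the other in this series. Among the compounds shown here, the step of a 4.3-fold higher number from compound 1 to compound 4 (0.64 log units; beyond the scatter) adds something the earlier compounds could not show, as it separates the methyl group of compound 1 from the outer ring, and it indicates that part of the low number of compound 1 goes with that methyl group rather than with the trifluoromethyl.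

From the compounds shown here alone, it remains open whether a nitrile, a methoxy group or a carboxylic acid at this position would give numbers like those of compound 2 and compound 4, and whether the methyl step would hold with chloro in place of trifluoromethyl. No measurement shown here bears on what lies behind these steps.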